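The compounds below may be only part of what the source reports. "The series", "measured", "known", "first", "only" and "open" are said of these compounds alone.

Measured compounds in this series:

compound 1 `CCOC(=O)COc1cc(O)c2c(=O)c(O)c(-c3ccc4c(c3)OC(c3ccc(OCC(=O)OCC)c(OC)c3)C(CO)O4)oc2c1`: 53.5%
compound 2 `COc1cc(C2Oc3cc(-c4oc5cc(OCC=C(C)C)cc(O)c5c(=O)c4O)ccc3OC2CO)ccc1O`: 51%
compound 3 `COc1cc(C2Oc3cc(-c4oc5cc(OCC(=O)N6CCCC6)cc(O)c5c(=O)c4O)ccc3OC2CO)ccc1OCC(=O)N1CCCC1`: 87%

Read-out throughout is a functional assay for inhibition, read by spectrophotometry, with a stated time of 10 min, tested at 150 uM; on this read-out lower numbers stand for less inhibition and higher numbers for more inhibition at the one concentration tested (going by the name of the read-out). Compound 2 has the lowest of the three numbers. Its nearest neighbour is compound 1, whose value lies within the scatter of that of compound 2, so no order between these two can be claimed. Compound 3 stands well apart, with a value beyond the scatter above that of compound 2.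

Compound 4 `CCN(CC)C(=O)COc1cc(O)c2c(=O)c(O)c(-c3ccc4c(c3)OC(c3ccc(O)c(OC)c3)C(CO)O4)oc2c1` has not been measured. It is derived from compound 2 by one change, (diethylcarbamoyl in place of 2-methylprop-1-en-1-yl on a saturated chain carbon bound to an oxygen on an aromatic ring). Going by the values given here, no measured pair in the set differs in a single place, so no directly comparable step exists. Compound 3, which carries a carboxamide-bearing chain on each of its two phenolic oxygens and gives 87%, is the only pointer towards what a carboxamide group may bring; compound 4 carries such a group on one side only. A moderate rise beyond the scatter in this assay is therefore expected for compound 4, with considerable uncertainty. The estimated step of a number 14 percentage points higher from compound 2 to compound 4 (beyond the scatter) puts compound 4 at an expected 65%, within a range of 48% to 82%.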

Compound 4, a percentage reported as inhibition, at one concentration (the size of the read-out at that concentration, not a potency): 52.5%
Compound 4: the middle estimate sits 12.5 percentage points above what was measured; the range from low to high includes it.
By their numbers in this assay, from the lowest: compounds 2, 4 and 1 (each within the scatter of the next); then compound 3.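

In this assay, going by these compounds alone, the only single-place step reads a number 1.5 percentage points higher from compound 2 to compound 4 (within the scatter). At this place, a saturated chain carbon bound to an oxygen on an aromatic ring, diethylcarbamoyl in place of 2-methylprop-1-en-1-yl therefore gives no difference that can be told from the scatter, even though the entering group has more heavy atoms and a hydrogen-bond acceptor that the leaving group lacks. No measurement at hand gives a reason for this result.

Compound 3 at 87% carries a carboxamide-bearing chain on each of its two phenolic oxygens and differs from compound 4 in more than one place, so what sets its value apart cannot be assigned to either chain. Also open, on these data alone, is how a carboxylic acid or a tertiary amine at this place would read in this assay.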